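Trifluoromethyl for Chloro: Cytotoxicity Across Two Benzimidazole Cores

This account rests on a few compounds, and the source may have more. Where it says the series, first, only, none or still open, it means among the compounds named here.

The study measures tolerance of the cells in an ADME assay on MDBK cells (Bos taurus) for cytotoxicity, read by MTT assay, with a stated time of 96 h; a lower number here means that less compound is tolerated, a higher number that more compound is tolerated. Compound 1, `C/C(=N\NC(N)=S)c1ccc2[nH]c(-c3ccc(Cl)cc3)nc2c1`, gives in this assay only a limit of the assay, > 100000 nM. Compound 2, `C/C(=N\NC(N)=S)c1ccc2[nH]c(-c3ccc(C(F)(F)F)cc3)nc2c1`, differs from compound 1 by the change (trifluoromethyl in place of chloro on an aromatic carbon). In this assay compound 2 gives 5000 nM. Among the measured compounds shown here, this step, an at least 20-fold lower number from compound 1 to compound 2 (1.30 log units; beyond the scatter), is the only numbered step among the measured compounds, and it rests on a starting point that is a limit, since (the limit of > 100000 nM in this assay, at which 2 of the 3 values shown sit).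

Compound 3, `C/C(=N\NC(N)=O)c1ccc2c(c1)nc(-c1ccc(Cl)cc1)n2C1CCCCC1`, carries a different core; the difference between the two cores is not broken down here. In this assay compound 3 gives only a limit of the assay, > 100000 nM. Compound 4, `C/C(=N\NC(N)=O)c1ccc2c(c1)nc(-c1ccc(C(F)(F)F)cc1)n2C1CCCCC1`, is not yet measured and differs from compound 3 by trifluoromethyl in place of chloro on an aromatic carbon. The place of the change is the same as between compound 1 and compound 2, so it is the same change on another core.

For compound 4 the value in this assay is expected near 10000 nM, because the same change on the first core gave compound 1 to compound 2 an at least 20-fold lower number from compound 1 to compound 2 (1.30 log units; beyond the scatter). The step this estimate means is expected to be an at least 10-fold lower number from compound 3 to compound 4 (1.00 log units; beyond the scatter). The lower end for compound 4 is expected near 2500 nM. The upper end for compound 4 is expected near 100000 nM, since the starting value of compound 3 is only a limit and the true tolerance of compound 3 may lie well past it.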

Compound 4, half-maximal cytotoxic concentration: > 100000 nM
Compound 4: no number, only a limit; the forecaster's own chance of this, stated with the estimate: 30%; middle value at least 10-fold (1.00 log units) from the limit.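

In this assay compound 4 gives only a limit of the assay, > 100000 nM. Compound 3 also stands at a limit, so no step from compound 3 to compound 4 can be read: the limit of > 100000 nM in this assay, at which 3 of the 4 values shown sit.

The compounds shown leave open whether trifluoromethyl in place of chloro changes the tolerated concentration on the core of compound 3 as it did on the core of compound 1.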